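The source may report more compounds than this note shows. Statements on the series, on what has been measured and on what is new or still open speak of the compounds shown alone.

Measured in a functional assay on ZR-75-30 cells (Homo sapiens) for cytotoxicity, read by MTT assay, with a stated time of 72 h; a higher number here means a weaker inhibitor, a lower number a stronger inhibitor:
Compound 1 `C[C@@H]1C[C@@H](O)[C@H]2C(C)(C)CCC[C@]2(C)[C@@]1(O)CCC1=CC(=O)OC1`: < 5 ug/mL
Compound 2 `CO[C@H]1C[C@@]2(CC[C@@]3(O2)[C@H](C)CC[C@H]2C(C)(C)[C@@H](OC(C)=O)CC[C@@]23C)[C@H](OC)O1`: < 5 ug/mL
Compound 3 `C[C@@H]1CC=C2C(C)(C)CCC[C@]2(C)[C@@]12CC[C@]1(COC(=O)C1)O2`: < 5 ug/mL

None of these three entries is an exact number, and the overall picture is the limit of < 5 ug/mL in this assay, at which 3 of the 3 values shown sit. No ranking among the three compounds can therefore be drawn.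

The starting point here is compound 2, which stands at < 5 ug/mL in this assay. That entry is a limit of the assay and not a number.

Compound 4 `CO[C@@H]1C[C@@]2(CC[C@@]3(O2)[C@H](C)CC[C@H]2C(C)(C)[C@@H](OC(C)=O)CC[C@@]23C)[C@H](OC)O1` has not yet been measured. Set against compound 2, its structure changes in only one way: the two compounds have the same atoms and bonds and differ only in configuration as drawn: 1 of 8 stereo elements differ; a stereocentre at a saturated ring carbon is drawn R in compound 2 and S in compound 4. Nothing is added or removed, so this pair tests a change in configuration alone.

For the measured compounds named here, no measured pair in this small set shows what such a change does in this assay. The expectation is therefore no step beyond the usual scatter, in either direction, and compound 4 may well be reported as a limit too. The estimated change is a step that the limit leaves unreadable from compound 2 to compound 4. For compound 4 the expected value is 3 ug/mL, with an estimated range from 1 ug/mL to 8 ug/mL.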

Compound 4, half-maximal inhibitory concentration: < 5 ug/mL
Compound 4 gave a limit, no number; the forecaster's own chance of this, stated with the estimate: 75%; the middle value does not contradict the limit.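

No step can be read from compound 2 to compound 4, because both entries are limits of the assay and not numbers: the limit of < 5 ug/mL in this assay, at which 4 of the 4 values shown sit.

The compounds shown leave open how strongly each one acts in this assay, and whether the configuration at that one saturated ring carbon matters there at all: the fact that compounds 2 and 4 differ only in the configuration as drawn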